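Swapping a Formylphenyl Arm for Naphthyl

The source may hold more compounds than are shown below. What is called first, only, known or untested is meant among the compounds shown, and "the series" means these compounds.

Of the compounds shown here, three sharing one core have been measured in a physicochemical assay for lipophilicity, using the shake flask method, in phosphate buffer, measured as octanol-water partition, with a stated time of 85 min, at pH 7.4; on this read-out higher numbers stand for higher lipophilicity and lower numbers for lower lipophilicity. Compound 1 `c1ccc(-c2cn3ccnc3c(-c3ccc4ncn(C5CCCCC5)c4c3)n2)cc1` gives 1.74. Compound 2 `COc1ccc(-c2cn3ccnc3c(-c3ccc4ncn(C5CCCCC5)c4c3)n2)cc1` gives 1.41, and compound 3 `O=Cc1ccc(-c2cn3ccnc3c(-c3ccc4ncn(C5CCCCC5)c4c3)n2)cc1` gives 1.5. The number for compound 3 sits between the other two, yet both gaps fall inside the scatter: a number 0.24 log units lower from compound 1 to compound 3 (within the scatter) and a number 0.09 log units higher from compound 2 to compound 3 (within the scatter). Compound 4 `c1ccc2c(-c3cn4ccnc4c(-c4ccc5ncn(C6CCCCC6)c5c4)n3)cccc2c1` differs from compound 3 by naphthalen-1-yl in place of 4-formylphenyl on an aromatic carbon. Of the measured steps only the formyl part bears on this change, through a number 0.24 log units lower from compound 1 to compound 3 (within the scatter), so undoing it points toward a small rise back toward compound 1; the second fused ring has no measured counterpart among these three. Compound 4 is therefore estimated at 2.5, between 1.9 and 3.1, a step expected as a number 1.00 log units higher from compound 3 to compound 4 (beyond the scatter).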

Compound 4, partition coefficient: 1.44
For compound 4 the middle estimate is 1.06 log units above the measured one, outside the stated range (below it).
By their numbers in this assay, from the lowest: compounds 2, 4, 3 and 1 (each within the scatter of the next, the first and the last beyond it).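

Replacing the arm at this position with naphthalen-1-yl, which has two six-membered aromatic rings of carbon only, gives a number in this assay within the scatter of all three other arms (a number 0.06 log units lower from compound 3 to compound 4 (within the scatter); a number 0.03 log units higher from compound 2 to compound 4 (within the scatter); a number 0.30 log units lower from compound 1 to compound 4 (within the scatter)). Among these four compounds, the only step beyond the scatter remains the one with methoxy (a number 0.33 log units lower from compound 1 to compound 2 (beyond the scatter)). Nothing available explains why the second ring leaves the number within the scatter. On these data alone, whether an amine or a carboxylic acid on this arm would give a larger step remains open.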